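Series notes: hydroxy in place of methoxy on the aryl

The source may report more compounds than this note shows. Statements on the series, on what has been measured and on what is new or still open speak of the compounds shown alone.

Compound 3 `COc1cc(-c2nn(-c3cccc(NC(=O)Nc4ccc(Cl)c(C(F)(F)F)c4)c3)cc2-c2ccncc2)ccc1Cl` carries a 4-chloro-3-methoxyphenyl group on the shared core. In a functional assay on PC-3 cells (Homo sapiens) for inhibition, read by sulforhodamine B assay, with a stated time of 48 h (a higher number here means that more compound is tolerated, a lower number that less compound is tolerated), compound 3 gives only a limit, > 32500 nM. Compound 1 `O=C(Nc1cccc(-n2cc(-c3ccncc3)c(-c3ccc(Cl)c(O)c3)n2)c1)Nc1cccc(C(F)(F)F)c1` also sits at a limit in this assay, > 32500 nM. Compound 2 `O=C(Nc1cccc(-n2cc(-c3ccncc3)c(-c3ccc(Cl)c(O)c3)n2)c1)Nc1ccc(Cl)c(Cl)c1` likewise reaches a limit, > 32500 nM. The step that the two limits leave unreadable from compound 1 to compound 2 cannot be sized. Compound 4 `O=C(Nc1cccc(-n2cc(-c3ccncc3)c(-c3ccc(Cl)c(O)c3)n2)c1)Nc1ccc(Cl)c(C(F)(F)F)c1` differs from compound 3 by hydrogen in place of methyl on an oxygen on an aromatic ring. Going by the values given here, no measured step covers this change directly; compounds 1 and 2, which already carry the hydroxy group, both sit at the same limit as compound 3 (the limit of > 32500 nM in this assay, at which 3 of the 3 values shown sit). Compound 4 is therefore expected to remain at the limit, an expected step that the limit leaves unreadable from compound 3 to compound 4 not beyond the scatter. The estimate for compound 4 in this assay is 50000 nM, between 25000 nM and 150000 nM.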

Compound 4, concentration lethal to 50% of the cells: > 32500 nM
Compound 4 ended at the assay's limit; the forecaster's own chance of this, stated with the estimate: 85%; the middle value lies beyond the limit too.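

Compounds 1, 2, 3 and 4 all sit at the same assay limit, and the steps from compounds 1, 2 and 3 to compound 4 cannot be read. Whether hydroxy in place of methoxy, or the chloro and trifluoromethyl changes, would shift the read-out in this assay at all stays open for the compounds shown.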